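The source may report more compounds than this note shows. Statements on the series, on what has been measured and on what is new or still open speak of the compounds shown alone.

Measured so far in an assay on isolated protein for inhibition of vitamin D3 receptor (Homo sapiens), read by fluorescence polarization; on this read-out higher numbers stand for weaker inhibition and lower numbers for stronger inhibition:
Compound 1, `CS(=O)(=O)c1ccc(C(=O)N2CCC(C(=O)N3CCN(c4ccc(F)cc4)CC3)CC2)cc1[N+](=O)[O-]`, gives > 60000 nM; this is a limit of the assay, not a number.
Compound 2, `CS(=O)(=O)c1ccc(C(=O)N2CCC(C(=O)N3CCc4ccccc4C3)CC2)cc1[N+](=O)[O-]`, gives > 60000 nM; this too is a limit, not a number.
Compound 3, `CN(Cc1ccccc1)C(=O)CNC(=O)c1ccc(S(C)(=O)=O)c([N+](=O)[O-])c1`, gives > 60000 nM; again a limit, not a number.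

Compound 2 stands exactly where every value shown stands: the limit of > 60000 nM in this assay, at which 3 of the 3 values shown sit. For the measured compounds named here, since none of the three values is a number, there is no measured step in this assay, no order among the three compounds, and no ground for calling any of them more or less active than another. The shared core, seen in compound 2, carries the aryl methylsulfonyl nitro amide with a saturated ring and a second amide in all three.

Compound 4, `CN1CCN(C(=O)C2CCN(C(=O)c3ccc(S(C)(=O)=O)c([N+](=O)[O-])c3)CC2)CC1`, is not yet measured in this assay. It differs from compound 2 in one place: 4-methylpiperazin-1-yl in place of 1,2,3,4-tetrahydroisoquinolin-2-yl on a carbonyl carbon. The amide on the carbonyl carbon whose other neighbour is a saturated ring carbon is thus kept, with 4-methylpiperazin-1-yl in place of 1,2,3,4-tetrahydroisoquinolin-2-yl.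

With only limits in hand, no direction or size of change can be read from the series, and the expected step from compound 2 to compound 4 is none beyond the scatter, a step that the limit leaves unreadable from compound 2 to compound 4. Compound 4 is therefore expected at roughly 100000 nM in this assay, within 30000 nM to 300000 nM, most probably reported again as a limit rather than a number.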

Compound 4, half-maximal inhibitory concentration: > 60000 nM
Compound 4 gave a limit, no number; the forecaster's own chance of this, stated with the estimate: 90%; the middle value lies beyond the limit too.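

Neither the step from compound 2 to compound 4 nor the step from compound 1 to compound 4 can be read in this assay, since each pair has only limits and no numbers: the limit of > 60000 nM in this assay, at which 4 of the 4 values shown sit.

The compounds shown leave open whether any change on the shared core gives a numerical value in this assay, and which groups, if any, bear on inhibition.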